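This account rests on a few compounds, and the source may have more. Where it says the series, first, only, none or still open, it means among the compounds named here.

In an ADME assay on HepG2 2.2.15 cells (Homo sapiens) for cytotoxicity (on this read-out higher numbers stand for lower toxicity in this test and lower numbers for higher toxicity in this test), compound 1 (`O=c1[nH]c2ccc(Cl)cc2c(-c2ccccc2Cl)c1CCO`) gives 380000 nM, compound 2 (`CC(C)C(=O)OCCc1c(-c2ccccc2Cl)c2cc(Cl)ccc2[nH]c1=O`) gives 62000 nM and compound 3 (`CCCCCCCC(=O)OCCc1c(-c2ccccc2Cl)c2cc(Cl)ccc2[nH]c1=O`) gives 78000 nM. Compound 3 therefore lies well under compound 1 and cannot be told apart from compound 2. Compound 4 (`N#CCC(=O)OCCc1c(-c2ccccc2Cl)c2cc(Cl)ccc2[nH]c1=O`) follows from compound 3 by one change: cyano in place of hexyl on a saturated chain carbon bound to a carbonyl carbon. The heptylcarbonyl group thus becomes (cyanomethyl)carbonyl, while the oxygen stays acylated. Two measured steps show what placing such a group on that oxygen did: a 6.1-fold lower number from compound 1 to compound 2 (0.79 log units; beyond the scatter) and a 4.9-fold lower number from compound 1 to compound 3 (0.69 log units; beyond the scatter), both modest. The step that bears most directly is the exchange on the carbonyl carbon, a 1.3-fold higher number from compound 2 to compound 3 (0.10 log units; within the scatter), which stays within the scatter despite the different chains. Within the data shown here, no measured compound carries a cyano group, so this comparison is only indirect. No step beyond the scatter is therefore expected, and the range is left wider on the upper side. The expected change is a 1.1-fold higher number from compound 3 to compound 4 (0.04 log units; within the scatter). For compound 4 the estimated value is 85000 nM, with an expected range of 40000 nM to 220000 nM.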

Compound 4, half-maximal cytotoxic concentration: 100000 nM
Compound 4: the middle estimate sits 1.2-fold (0.07 log units) below what was measured; the range from low to high includes it.
By their numbers in this assay, from the lowest: compounds 2, 3 and 4 (each within the scatter of the next); then compound 1.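

In this assay, cyano in place of hexyl gives a 1.3-fold higher number from compound 3 to compound 4 (0.11 log units; within the scatter) and cyanomethyl in place of isopropyl gives a 1.6-fold higher number from compound 2 to compound 4 (0.21 log units; within the scatter) in the same test, so a nitrile at the end of the acyl chain stays within the scatter of both plain carbon chains. The hydrogen on the oxygen of compound 1 remains the change that can be read, since a 3.8-fold lower number from compound 1 to compound 4 (0.58 log units; beyond the scatter) and thus joins the two earlier modest steps, which makes all three acylated compounds stand apart from compound 1. No measurement shown gives a reason for these numbers.

On these data alone, whether an amine or a carboxylic acid on that saturated chain carbon would stay with compounds 2, 3 and 4 remains open. So does the effect of a benzoyl group, or of an acyl chain longer than heptyl, on this oxygen.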